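The source may hold more compounds than are shown below. What is called first, only, known or untested is meant among the compounds shown, and "the series" means these compounds.

Measured so far: compound 1 `N#Cc1ccc(F)cc1Cn1c(N2CCC[C@@H](N)C2)nc2cc[nH]c2c1=O`, 3.33 h; compound 2 `N#Cc1ccc(F)cc1Cn1c(N2CCC[C@@H](N)C2)nc2c(F)c[nH]c2c1=O`, 1.64 h.

In an ADME assay on microsomes from liver (Homo sapiens) for metabolic stability, read by LC-MS, tested at 1 mM (on this read-out lower numbers stand for a shorter-lived compound and higher numbers for a longer-lived compound), compound 1 gives 3.33 h, the higher of the two numbers. Compound 2 gives 1.64 h. Going by the values given here, the one step in the set is a 2.0-fold lower number from compound 1 to compound 2 (0.31 log units; beyond the scatter). Compound 3 `CS(=O)(=O)c1cccc(-c2c[nH]c3c(=O)n(Cc4cc(F)ccc4C#N)c(N4CCC[C@@H](N)C4)nc23)c1` differs from compound 1 by 3-(methylsulfonyl)phenyl in place of hydrogen on an aromatic carbon. Among the compounds with values here, no measured step matches this change; the only step available, fluoro for hydrogen on the five-membered aromatic ring with 1 nitrogen, lowered the number modestly. A drop of similar or somewhat larger size is therefore expected, a 1.9-fold lower number from compound 1 to compound 3 (0.27 log units; within the scatter). Compound 3 is estimated at 1.8 h, range 0.7 h to 4.5 h.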

Compound 3, half-life: > 3.33 h
Compound 3: a limit, no number; the forecaster's own chance of this, stated with the estimate: 5%; middle value at least 1.8-fold (0.26 log units) from the limit.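

In this assay compound 3 gives > 3.33 h, which is a limit and not a number. With 3-(methylsulfonyl)phenyl in place of fluoro on this aromatic carbon, the result is an at least 2.0-fold higher number from compound 2 to compound 3 (0.30 log units; that floor lies within the scatter), so this position carries a large aryl group without the fall seen with fluoro. Against hydrogen the result is a number no lower from compound 1 to compound 3 (the limit leaves the size open), and the size of that step cannot be read: the limit of > 3.33 h in this assay, at which 1 of the 3 values shown sits.

Going by these compounds, how far compound 3 lies past its limit stays open. Also open, on these data alone, is whether an unsubstituted phenyl, or a phenyl bearing an amine or a carboxylic acid, would behave the same way at this carbon.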